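Ring size of the dithiocarbamate amine in chromone series

The source may hold more compounds than are shown below. What is called first, only, known or untested is meant among the compounds shown, and "the series" means these compounds.

Three chromone dithiocarbamates have been measured in a functional assay on HEp-2 cells (Homo sapiens) for antiproliferative activity, read by MTT assay, with a stated time of 72 h; on this read-out higher numbers stand for weaker inhibition and lower numbers for stronger inhibition. Compound 1 `O=c1cc(CSC(=S)N2CCCCC2)oc2cc(Cl)ccc12` gives 1600 nM. Compound 2 `O=c1c(Cl)c(CSC(=S)N2CCCC2)oc2ccccc12` gives 600 nM, and compound 3 `O=c1c(CSC(=S)N2CCN(C(c3ccc(F)cc3)c3ccc(F)cc3)CC2)coc2ccccc12` gives 9600 nM. Compound 1 thus stands second highest of the three numbers: compound 2 sits below it by more than the scatter, and compound 3 sits above it by a larger margin, also beyond the scatter.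

Compound 4 `O=c1cc(CSC(=S)N2CCCC2)oc2cc(Cl)ccc12` is not yet measured. It differs from compound 1 in one place: pyrrolidin-1-yl in place of piperidin-1-yl on a thiocarbonyl carbon. Going by the values given here, compound 2 also carries pyrrolidin-1-yl and gives the lowest number so far, but it differs from compound 1 in more than this one place, so no step for the ring change alone is known. The change is small in size, and on the numbers shown a step from compound 1 to compound 4 of no more than the scatter is expected, perhaps leaning toward a lower number.

The estimate for compound 4 in this assay is 1200 nM, within 500 nM to 3000 nM, which would mean an expected step of a 1.3-fold lower number from compound 1 to compound 4 (0.12 log units; within the scatter).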

Compound 4, half-maximal inhibitory concentration: > 40000 nM
Compound 4: no number, only a limit (the forecaster's own chance of this, stated with the estimate: 5%); middle value at least 33-fold (1.52 log units) from the limit.
By their numbers in this assay, from the lowest: compound 2; then compound 1; then compound 3. At a limit, above all of these: compound 4.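

In this assay, pyrrolidin-1-yl in place of piperidin-1-yl on a thiocarbonyl carbon gives an at least 25-fold higher number from compound 1 to compound 4 (1.39 log units; beyond the scatter), so this single ring change on the core of compound 1 is a large step and the position is sensitive to it. The step is bounded on one side only, as compound 4 gives a limit and not a number: the limit of > 40000 nM in this assay, at which 1 of the 4 values shown sits.

The compounds shown hold no second pair with this ring change, so the step is tied to the core of compound 1 alone.

Going by these compounds, what the same change does on the cores of compound 2 and compound 3 stays open, as does the outcome with a morpholin-4-yl ring or an open-chain diethylamino group at this position. Nothing shown gives the reason for the step.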